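The source may report more compounds than this note shows. Statements on the series, on what has been measured and on what is new or still open speak of the compounds shown alone.

Compound 1, `CCc1ccc(C(=O)Nc2ccc(C)c(-n3cc(-c4cccnc4)cn3)c2)cc1`, gives in a functional assay on K562 cells (Homo sapiens) for inhibition, read by MTT assay, with a stated time of 48 h (on this read-out lower numbers stand for stronger inhibition and higher numbers for weaker inhibition), a value of 6520 nM. Compound 2, `Cc1ccc(NC(=O)c2ccc(CN3CCN(C)CC3)cc2)cc1-n1cc(-c2cccnc2)cn1`, gives in this assay a value of 1670 nM. For the measured compounds named here, the one measured step, a 3.9-fold lower number from compound 1 to compound 2 (0.59 log units; beyond the scatter), carries the 4-methylpiperazin-1-yl group onto the saturated chain carbon bound to an aromatic carbon. Going by the values given here, on the two numbers in hand, compound 2 stands lowest, with compound 1 as its only neighbour at the higher number just given.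

Compound 3, `Cc1ccc(NC(=O)c2ccc(CN3CCCN(C)CC3)cc2)cc1-n1cc(-c2cccnc2)cn1`, differs from compound 2 by 4-methyl-1,4-diazepan-1-yl in place of 4-methylpiperazin-1-yl on a saturated chain carbon bound to an aromatic carbon. Among the compounds with values here, no measured step covers a change of this kind; the one available step, from compound 1 to compound 2, concerns putting the 4-methylpiperazin-1-yl group in place of methyl, not enlarging its ring, so it gives only indirect guidance. The change from compound 2 to compound 3 keeps the donor and acceptor count the same and alters only the size of the saturated ring, so in this assay no step beyond the scatter is expected, in either direction. The step from compound 2 to compound 3 is accordingly estimated as a 1.0-fold higher number from compound 2 to compound 3 (0.01 log units; within the scatter). Compound 3 is therefore expected to give about 1700 nM, within a range from 600 nM to 5000 nM.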

Compound 3, half-maximal inhibitory concentration: 8650 nM
Estimate against measurement, compound 3: 5.1-fold (0.71 log units) below; the measured number lies above the stated range.
By their numbers in this assay, from the lowest: compound 2; then compounds 1 and 3 (each within the scatter of the next).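

In this assay, the group on the saturated chain carbon bound to an aromatic carbon proves sensitive to ring size: replacing the six-membered ring of 4-methylpiperazin-1-yl with the seven-membered ring of 4-methyl-1,4-diazepan-1-yl gives a 5.2-fold higher number from compound 2 to compound 3 (0.71 log units; beyond the scatter), even though the hydrogen-bond donor and acceptor counts and the net charge stay the same. The gain seen on installing 4-methylpiperazin-1-yl therefore does not extend to this closely related ring: putting 4-methyl-1,4-diazepan-1-yl in place of methyl gives a 1.3-fold higher number from compound 1 to compound 3 (0.12 log units; within the scatter), so the simple ethyl-bearing compound 1 and the larger compound 3 cannot be told apart. No measurement is available that could explain the difference between the two rings.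

From the compounds shown here alone, it remains open how a piperidine, morpholine or pyrrolidine ring on the same chain carbon would read in this assay, and so whether the six-membered ring or its second nitrogen matters more. Also open, going by these compounds, is whether a group other than methyl on the far ring nitrogen of 4-methylpiperazin-1-yl, such as a hydroxyethyl chain, would lower the number further.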